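The compounds below may be only part of what the source reports. "The series", "measured", "known", "first", "only" and "open" are said of these compounds alone.

Series notes. All three measured compounds share a core in which two arylidene groups sit on a cyclohexanone. Compound 1 `COc1cccc(/C=C2\CCC/C(=C\c3ccccc3Cl)C2=O)c1OC` carries a 2-chlorophenyl on one side and in a functional assay on MCF7 cells (Homo sapiens) for cytotoxicity, read by MTT assay, with a stated time of 72 h (a lower number here means a stronger inhibitor, a higher number a weaker inhibitor), compound 1 gives 11300 nM. Compound 2 `COc1ccccc1/C=C1\CCC/C(=C\c2cccc(OC)c2OC)C1=O` differs from compound 1 by methoxy in place of chloro on an aromatic carbon, and compound 2 gives 12000 nM; the step of a 1.1-fold higher number from compound 1 to compound 2 (0.03 log units; within the scatter). Compound 3 `COc1cccc(/C=C2\CCC/C(=C\c3ccc(O)c(Cl)c3)C2=O)c1OC` differs from compound 1 by 3-chloro-4-hydroxyphenyl in place of 2-chlorophenyl on a double-bonded chain carbon bound to a double-bonded ring carbon, and compound 3 gives 16400 nM; the steps of a 1.5-fold higher number from compound 1 to compound 3 (0.16 log units; within the scatter) and a 1.4-fold higher number from compound 2 to compound 3 (0.14 log units; within the scatter). None of the three numbers is separated from another beyond the scatter, so no order among compounds 1, 2 and 3 is claimed.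

Compound 4 `COc1cc(/C=C2\CCC/C(=C\c3cccc(OC)c3OC)C2=O)ccc1O` has not been measured. It differs from compound 3 by methoxy in place of chloro on an aromatic carbon. This is the same kind of change as that from compound 1 to compound 2, but the surroundings differ: in compound 1 the replaced chloro is ortho to a large group, whereas in compound 3 it is ortho to a hydroxy group (1 heavy atom) and meta to a large group.

Going by the values given here, the one measured instance of this change, a 1.1-fold higher number from compound 1 to compound 2 (0.03 log units; within the scatter), stayed within the scatter. On that basis the step from compound 3 to compound 4 is expected to be similarly small, a 1.0-fold higher number from compound 3 to compound 4 (0.02 log units; within the scatter), with added uncertainty because methoxy in place of chloro on an aromatic carbon sits in a different environment. Compound 4 is therefore estimated at 17000 nM, with a likely range from 9000 nM to 33000 nM.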

Compound 4, half-maximal inhibitory concentration: 11600 nM
Compound 4: middle estimate off by 1.5-fold (0.17 log units), on the high side; measured number inside the range.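

In this assay, methoxy in place of chloro on an aromatic carbon can now be read on two cores, and the two steps do not differ beyond the scatter: the same change on two cores in this assay, a 1.1-fold higher number (0.03 log units; within the scatter) from compound 1 to compound 2 and a 1.4-fold lower number (0.15 log units; within the scatter) from compound 3 to compound 4, 1.5-fold (0.18 log units) apart, within the scatter of two such steps. The new step, a 1.4-fold lower number from compound 3 to compound 4 (0.15 log units; within the scatter), stays within the scatter, as do the two exchanges of a whole aryl group, a 1.0-fold lower number from compound 2 to compound 4 (0.01 log units; within the scatter) and a 1.0-fold higher number from compound 1 to compound 4 (0.01 log units; within the scatter), so all four compounds remain unordered in this assay. Going by these compounds alone, this shows that the change carried across these two cores without a resolvable difference, but it does not show that the change has no effect in general or would carry to other cores, since it rests on only two small steps in one assay on one cell line.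

All steps among the four compounds lie within the scatter, so the series shown gives no substituent exchange that separates one compound from another, and it remains open whether an amine, a carboxylic acid or a longer alkoxy chain on the aromatic rings would give a step beyond the scatter. Also open, from the compounds shown here alone, is whether replacing the shared cyclohexanone core with another ring would leave the methoxy for chloro step as small as it is here.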